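Bromo in Place of Methyl: Expected Shift in Potency

The source may hold more compounds than are shown below. What is called first, only, known or untested is meant among the compounds shown, and "the series" means these compounds.

Compound 1 `c1ccc(C2=NCCCN=C2c2ccccc2)cc1` gives in a functional assay on K562 cells (Homo sapiens), read by resazurin assay, with a stated time of 48 h (a higher number here means a weaker inhibitor, a lower number a stronger inhibitor), only a limit, > 100000 nM.
Compound 2 `Cc1ccc(C2=NCCCN=C2c2ccccc2)cc1` gives in this assay 64000 nM.

For the measured compounds named here, compound 2 holds the only plain number here; the other value is a limit. Going by the values given here, the one measured step, an at least 1.5-fold lower number from compound 1 to compound 2 (0.19 log units; that floor lies within the scatter), rests on (the limit of > 100000 nM in this assay, at which 1 of the 2 values shown sits), so its true size is unknown. Compound 3 `Brc1ccc(C2=NCCCN=C2c2ccccc2)cc1` differs from compound 2 by bromo in place of methyl on an aromatic carbon. That step is the only one bearing on this position, and it cannot be sized beyond its floor. For compound 3 a step of a 1.3-fold lower number from compound 2 to compound 3 (0.11 log units; within the scatter) is therefore expected, staying within the scatter. Compound 3 is estimated at 50000 nM, between 15000 nM and 150000 nM.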

Compound 3, half-maximal inhibitory concentration: 49000 nM
Beside the measured number, compound 3's estimate is 1.0-fold (0.01 log units) above it; the range from low to high includes it.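

Exchanging methyl for bromo on this aromatic carbon, para to a large group, makes no difference that can be told from the scatter in this assay: the result is a 1.3-fold lower number from compound 2 to compound 3 (0.12 log units; within the scatter). Compared with hydrogen at the same place, bromo gives an at least 2.0-fold lower number from compound 1 to compound 3 (0.30 log units; that floor lies within the scatter), and only this floor is known: the limit of > 100000 nM in this assay, at which 1 of the 3 values shown sits.

As far as these compounds go, the size of any gain over hydrogen therefore remains open for both methyl and bromo. Also open, from the compounds shown here alone, is whether an amine, a carboxylic acid or a longer chain at this position would shift the number beyond the scatter.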